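Moving from a methylpyrazole to a methylimidazole on compound 2

A few compounds are considered here, and "the series" means these few. Any claim that something is new, unique, unknown or untested is made for them only; others in the source may bear on it.

In a physicochemical assay for lipophilicity, using the shake flask method, in phosphate buffer, measured as octanol-water partition, with a stated time of 30 min, at pH 7.4 (a lower number here means a more polar compound, a higher number a more lipophilic compound), compound 2 `Cn1cc(-c2cnc(NCc3c(F)ccc4c3CCO4)c3cn[nH]c(=O)c23)cn1` gives 2.7, the second highest of three numbers. Compound 3 `CN(c1ncco1)c1cnc(NCc2c(F)ccc3c2CCO3)n2cnnc12` gives 2.1, and compound 1 `O=C(Nc1ccccc1)c1cnc(NCc2c(F)ccc3c2CCO3)n2cnnc12` gives 4.1. Compound 4 `Cc1nccn1-c1cnc(NCc2c(F)ccc3c2CCO3)c2cn[nH]c(=O)c12`, not yet measured, has the same atoms as compound 2, joined differently: 2-methyl-1H-imidazol-1-yl in place of 1-methyl-1H-pyrazol-4-yl on an aromatic carbon. The swap sits on an aromatic carbon of the shared core. Going by the values given here, the only measured step, a number 2.00 log units lower from compound 1 to compound 3 (beyond the scatter), is large, but it exchanges other groups on a different core. It shows that one exchange can move this assay far, yet it gives no direct size for this swap. The expected step is a modest fall, a number 0.40 log units lower from compound 2 to compound 4 (beyond the scatter). Compound 4 is therefore estimated at 2.3, within a range of 1.8 to 2.8.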

Compound 4, distribution coefficient: 2.1
Beside the measured number, compound 4's estimate is 0.20 log units above it; the range from low to high includes it.
By their numbers in this assay, from the lowest: compounds 3 and 4 (each within the scatter of the next); then compound 2; then compound 1.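

At this aromatic carbon, this assay records a number 0.60 log units lower from compound 2 to compound 4 (beyond the scatter) when 2-methyl-1H-imidazol-1-yl enters in place of 1-methyl-1H-pyrazol-4-yl. Going by these compounds alone, this is the first size read directly for a change at this position, and it shows that two groups with the same atoms and the same counted features, joined differently, can still give numbers that lie beyond the scatter. Nothing shown accounts for the step. From the compounds shown here alone, whether an amine or a carboxylic acid at this position would move the number further remains open, as does whether this swap would give a similar step on the core of compound 1.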